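Carboxy Replaces Hydroxyethyl on the Amine Side Chain

This account rests on a few compounds, and the source may have more. Where it says the series, first, only, none or still open, it means among the compounds named here.

Going by the values given here, compound 3 `CC(C)(C)c1ccc(S(=O)(=O)Nc2ccc(Cl)cc2-c2nccnc2NCCCO)cc1` gives 614 nM in a functional assay on isolated protein for antagonist activity at C-C chemokine receptor type 9 (Homo sapiens), read by calcium flux, with a stated time of 10 min (on this read-out lower numbers stand for stronger inhibition and higher numbers for weaker inhibition), the highest of the three numbers measured so far. Compound 1 `CNc1nccnc1-c1cc(Cl)ccc1NS(=O)(=O)c1ccc(C(C)(C)C)cc1` gives 25 nM, and compound 2 `CCNc1nccnc1-c1cc(Cl)ccc1NS(=O)(=O)c1ccc(C(C)(C)C)cc1` gives 421 nM. Two steps were large: a 17-fold higher number from compound 1 to compound 2 (1.23 log units; beyond the scatter) and a 25-fold higher number from compound 1 to compound 3 (1.39 log units; beyond the scatter), both adding a group at the carbon bound to the ring nitrogen. By contrast a 1.5-fold higher number from compound 2 to compound 3 (0.16 log units; within the scatter) stayed within the scatter. Compound 4 `CC(C)(C)c1ccc(S(=O)(=O)Nc2ccc(Cl)cc2-c2nccnc2NCC(=O)O)cc1` carries carboxy in place of 2-hydroxyethyl on a saturated chain carbon bound to a nitrogen on an aromatic ring. Among the compounds with values here, no measured step swaps one group at that carbon for another, so the best guide is a 1.5-fold higher number from compound 2 to compound 3 (0.16 log units; within the scatter), where a change further out on the chain moved little. A step of a 1.1-fold higher number from compound 3 to compound 4 (0.06 log units; within the scatter) is therefore expected, with no clear direction. Compound 4 is estimated at 700 nM, within 200 nM to 2500 nM.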

Compound 4, half-maximal inhibitory concentration: 812 nM
Estimate against measurement, compound 4: 1.2-fold (0.06 log units) below; the measured number falls inside the stated range.
By their numbers in this assay, from the lowest: compound 1; then compounds 2, 3 and 4 (each within the scatter of the next).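

Carboxy in place of 2-hydroxyethyl on a saturated chain carbon bound to a nitrogen on an aromatic ring gives a 1.3-fold higher number from compound 3 to compound 4 (0.12 log units; within the scatter), and carboxy in place of methyl at that carbon gives a 1.9-fold higher number from compound 2 to compound 4 (0.29 log units; within the scatter). So a group with a second oxygen and a double bond still falls in with compound 2 and compound 3, while compound 1, with only hydrogen at that carbon, stands apart: a 32-fold higher number from compound 1 to compound 4 (1.51 log units; beyond the scatter).

Nothing shown explains why these three side chains read alike. As far as these compounds go, whether an amine or an amide on this chain would also read alike remains open.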